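The source may report more compounds than this note shows. Statements on the series, on what has been measured and on what is new or still open speak of the compounds shown alone.

Measured in a functional assay on OVCAR-8 cells (Homo sapiens) for antiproliferative activity; on this read-out lower numbers stand for stronger inhibition and higher numbers for weaker inhibition:
compound 1 `CC(=O)NCC[C@@H]1C[C@@H](c2ccc(F)c(F)c2)[C@H](NC(=O)c2cc(-c3c(Cl)cnn3C)c(Cl)o2)CN1`: 880 nM
compound 2 `Cn1ncc(Cl)c1-c1cc(C(=O)N[C@@H]2CN[C@H](CC(N)=O)C[C@H]2c2ccc(Cl)c(Cl)c2)oc1Cl`: 1000 nM
compound 3 `Cn1ncc(Cl)c1-c1cc(C(=O)N[C@@H]2CN[C@H](CC(=O)NC3CCC3)C[C@H]2c2ccc(Cl)c(Cl)c2)oc1Cl`: 610 nM

Compound 3 gives the smallest of the three numbers, but its gaps to compound 1 and to compound 2 are both within the scatter, so none of the three stands apart in this assay. Among the measured compounds shown here, the only single-point step measured, a 1.6-fold lower number from compound 2 to compound 3 (0.21 log units; within the scatter), also stays within the scatter. For the measured compounds named here, compound 1 differs from compound 3 in its side chain at more than one point, and no single step connects the two; their values simply sit close together.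

Compound 4 `CCC[C@@H]1C[C@@H](c2ccc(Cl)c(Cl)c2)[C@H](NC(=O)c2cc(-c3c(Cl)cnn3C)c(Cl)o2)CN1` is the next entry: ethyl in place of cyclobutylcarbamoyl on a saturated chain carbon bound to a saturated ring carbon. Here the whole amide-bearing group of the side chain is lost, which none of the measured steps does; the step from compound 2 to compound 3 only changes the substituent on the amide-type nitrogen. From the compounds shown here alone, what the measured series shows is that variation around that amide has stayed within the scatter; whether removing it entirely moves the number is untested. The expectation for compound 4 is therefore a step of about a 1.2-fold higher number from compound 3 to compound 4 (0.09 log units; within the scatter) in this assay, with a wide range because of how little bears on it. Compound 4 is estimated at 750 nM, between 250 nM and 2500 nM.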

Compound 4, half-maximal inhibitory concentration: 1620 nM
Compound 4: middle estimate off by 2.2-fold (0.33 log units), on the low side, and the stated range covers the measured number.
By their numbers in this assay, from the lowest: compounds 3, 1, 2 and 4 (each within the scatter of the next, the first and the last beyond it).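

In this assay, among the compounds shown here, ethyl in place of cyclobutylcarbamoyl on a saturated chain carbon bound to a saturated ring carbon gives a 2.7-fold higher number from compound 3 to compound 4 (0.42 log units; beyond the scatter) and is the first step to lie beyond the scatter. The earlier compounds shown here varied only the substituent on the amide-type nitrogen, whereas this step shows that the number at this position can respond when the whole amide-bearing group is lost. The same replacement starting from the unsubstituted carbamoyl gives a 1.6-fold higher number from compound 2 to compound 4 (0.21 log units; within the scatter) and stays within the scatter, so the effect of losing the amide is read beyond the scatter only against compound 3 and not against compound 2. No measurement at hand accounts for this step.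

Open, from the compounds shown here alone, is whether a different group at this place, such as a primary amine, a carboxylic acid or a longer alkyl chain, would stay close to compound 3 at 610 nM or fall nearer to compound 4. Also open, going by these compounds, is how other substituents on the amide nitrogen, such as cyclopentyl or phenyl, would compare with cyclobutyl.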